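Pyrrolidinyloxy addition on the anilino ring of compound 3

The source may report more compounds than this note shows. Statements on the series, on what has been measured and on what is new or still open speak of the compounds shown alone.

Among the measured compounds shown here, in an assay on isolated protein for inhibition of ribosomal protein S6 kinase alpha-2 (Homo sapiens), with a stated time of 150 min (on this read-out higher numbers stand for weaker inhibition and lower numbers for stronger inhibition), compound 3 `COc1ccc(Nc2nc3cccc(-c4c(F)cccc4OC)c3o2)cc1` gives 1400 nM, the second highest of the three numbers so far. The unsubstituted parent compound 1 `COc1cccc(F)c1-c1cccc2nc(N)oc12` gives 2800 nM; the step of a 2.0-fold lower number from compound 1 to compound 3 (0.30 log units; within the scatter) is within the scatter, so these two are not ordered against each other. Compound 2 `COc1cccc(Nc2nc3cccc(-c4c(F)cccc4OC)c3o2)n1` gives 620 nM; the steps of a 4.5-fold lower number from compound 1 to compound 2 (0.65 log units; beyond the scatter) and a 2.3-fold higher number from compound 2 to compound 3 (0.35 log units; beyond the scatter) set it apart from both others.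

Compound 4 `COc1ccc(Nc2nc3cccc(-c4c(F)cccc4OC)c3o2)cc1O[C@H]1CCNC1` differs from compound 3 in one place: (pyrrolidin-3-yl)oxy in place of hydrogen on an aromatic carbon. For the measured compounds named here, no measured step addresses a substituent on this ring; all three measured steps exchange the group on the nitrogen. Their sizes are modest, a 4.5-fold lower number from compound 1 to compound 2 (0.65 log units; beyond the scatter) and a 2.3-fold higher number from compound 2 to compound 3 (0.35 log units; beyond the scatter), while a 2.0-fold lower number from compound 1 to compound 3 (0.30 log units; within the scatter) lies within the scatter. The series therefore gives no direction for this change, and the expected step is a 1.4-fold lower number from compound 3 to compound 4 (0.15 log units; within the scatter), taken as none beyond the scatter, with a wide range. Compound 4 is expected to give 1000 nM, between 250 nM and 4000 nM.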

Compound 4, half-maximal inhibitory concentration: 10 nM
Compound 4: the middle estimate sits 100-fold (2.00 log units) above what was measured; the measured number lies below the stated range.
By their numbers in this assay, from the lowest: compound 4; then compound 2; then compounds 3 and 1 (each within the scatter of the next).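

In this assay, (pyrrolidin-3-yl)oxy on the aromatic carbon ortho to a methoxy group gives a 140-fold lower number from compound 3 to compound 4 (2.15 log units; beyond the scatter), a far larger step than any of the earlier ones, all of which exchange the group on the nitrogen. This carbon therefore accepts a substituent of this size, and the read-out responds much more strongly here than to those exchanges. No measurement in hand accounts for the size of this step.

Open, from the compounds shown here alone, is which part of the group carries the step: a cyclopentyloxy would remove the ring amine, and a 2-aminoethoxy would keep an amine without the ring. Also open, going by these compounds, are the opposite configuration at the defined stereocentre and whether the same group gives a similar step on the 6-methoxypyridin-2-yl analogue, compound 2.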